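This account rests on a few compounds, and the source may have more. Where it says the series, first, only, none or still open, it means among the compounds named here.

Values measured in a functional assay on RAW264.7 cells (Mus musculus) for inhibition; on this read-out lower numbers stand for stronger inhibition and higher numbers for weaker inhibition:

- Compound 1 `CCOC(=O)C1=CCCCC1S(=O)(=O)Nc1ccc(Cl)cc1Cl`: 20 nM
- Compound 2 `CCOC(=O)C1=C(S(=O)(=O)Nc2ccc(Cl)cc2F)CCCC1`: 1700 nM
- Compound 3 `COC(=O)C1=CCCCC1S(=O)(=O)Nc1ccc(F)cc1F`: 57 nM

Compound 3, at 57 nM, stands in the middle of these three numbers. Compound 1 has a lower number and compound 2 a much higher one, both gaps lying beyond the scatter.

Compound 4 `O=C(OCCO)C1=CCCCC1S(=O)(=O)Nc1ccc(F)cc1F` has not yet been measured. It differs from compound 3 in one place: hydroxymethyl in place of hydrogen on a saturated chain carbon bound to an oxygen next to a carbonyl group. The methoxycarbonyl group thus becomes (2-hydroxyethoxy)carbonyl.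

Among the compounds with values here, no two measured compounds differ in just one place, so the data give no direct measure of a change like this one. Compound 1 and compound 3 differ in more than one place, including the ester. Compound 2 stands at 1700 nM, and the numbers of compound 1 and compound 3 are both far lower. The estimate is therefore loose. A modest rise in this assay is expected, meaning somewhat weaker inhibition, with the expected step being a 1.9-fold higher number from compound 3 to compound 4 (0.29 log units; within the scatter). For compound 4 the estimated value is 110 nM, with an expected range of 30 nM to 400 nM.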

Compound 4, half-maximal inhibitory concentration: 330 nM
Compound 4: middle estimate off by 3.0-fold (0.48 log units), on the low side, and the stated range covers the measured number.
By their numbers in this assay, from the lowest: compound 1; then compound 3; then compound 4; then compound 2.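

In this assay, within the data shown here, changing methoxycarbonyl to (2-hydroxyethoxy)carbonyl gives a 5.8-fold higher number from compound 3 to compound 4 (0.76 log units; beyond the scatter), the first direct reading of a single change in this set. It shows that this place on the ester is sensitive: adding hydroxymethyl here, with the rest of the molecule unchanged, weakens inhibition by more than the usual scatter. The data shown offer no independent measurement that could explain this loss.

A single step cannot separate the effect of the longer chain from that of its terminal hydroxyl group, so a 2-methoxyethyl ester or a propyl ester would be informative comparisons. Going by these compounds, how a 2-aminoethyl ester or a free carboxylic acid would behave also stays open, as does whether the same change would cost as much on the core of compound 1.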